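A Hydroxy Group Added to Compound 1

The compounds below may be only part of what the source reports. "The series", "measured", "known", "first", "only" and "open" are said of these compounds alone.

Compound 1 (`C#CCOc1ccc(C(=O)/C=C/c2ccccc2)cc1`) has been tested in a functional assay on HeLa cells (Homo sapiens) for inhibition, read by CCK-8 assay, with a stated time of 48 h; on this read-out lower numbers stand for stronger inhibition and higher numbers for weaker inhibition. There compound 1 gives > 50000 nM, which is a limit and not a number. Compound 2 (`C#CCOc1ccc(C(=O)/C=C/c2ccc(Cl)c(Cl)c2)cc1`) gives > 50000 nM, which is likewise a limit. The record so far therefore comes down to the limit of > 50000 nM in this assay, at which 2 of the 2 values shown sit, and it fixes no numerical position for compound 1. Going by the values given here, no measured step between compounds is available to serve as a guide.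

Compound 3 (`C#CCOc1ccc(C(=O)/C=C/c2ccccc2)c(O)c1`) keeps the core of compound 1 with one change: hydroxy in place of hydrogen on an aromatic carbon, ortho to a large group and meta to a propargyloxy group (hydroxy in place of hydrogen on an aromatic carbon).

In this assay only a small shift toward stronger inhibition is expected, and it may stay within the usual scatter. The estimated step is an at least 1.4-fold lower number from compound 1 to compound 3 (0.15 log units; that floor lies within the scatter). This expectation rests on nothing firmer than the limit of compound 1 at > 50000 nM, so another limit would be no surprise. Compound 3 is estimated at 35000 nM, with an expected range from 12000 nM to 60000 nM.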

Compound 3, half-maximal inhibitory concentration: > 50000 nM
Compound 3 ended at the assay's limit (the forecaster's own chance of this, stated with the estimate: 55%); middle value at least 1.4-fold (0.15 log units) away from the limit.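

Compound 1 and compound 3 both end at a limit in this assay and not at a number, so no step can be read between them. The record now stands as follows: the limit of > 50000 nM in this assay, at which 3 of the 3 values shown sit. The compounds shown leave open whether hydroxy in place of hydrogen on an aromatic carbon changes inhibition at all.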